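A few compounds are considered here, and "the series" means these few. Any claim that something is new, unique, unknown or untested is made for them only; others in the source may bear on it.

For the measured compounds named here, in an assay on Huh-7 cells for agonist activity at Bile acid receptor (Homo sapiens), read by a luciferase reporter (a higher number here means that more compound is needed for the effect, a lower number that less compound is needed), compound 2 `CC(C)c1onc(-c2c(Cl)cccc2Cl)c1COc1ccc(-c2nc3ccc(C(=O)O)cc3n2C(C)C)cc1` gives 3.39 nM, the lowest of the two numbers measured so far; compound 1 `CC(C)c1onc(-c2c(Cl)cccc2Cl)c1COc1ccc(-c2nc3ccc(C(=O)O)cc3n2CC2CC2)cc1` gives 19.4 nM. Going by the values given here, the one step measured, a 5.7-fold lower number from compound 1 to compound 2 (0.76 log units; beyond the scatter), shows that the group on the aromatic nitrogen matters, the isopropyl giving the lower number than the cyclopropylmethyl. Compound 3 `CC(=O)N1CCC(n2c(-c3ccc(OCc4c(-c5c(Cl)cccc5Cl)noc4C(C)C)cc3)nc3ccc(C(=O)O)cc32)CC1` changes this same aromatic nitrogen again: 1-acetylpiperidin-4-yl in place of isopropyl on an aromatic nitrogen. Among the compounds with values here, the step from compound 1 to compound 2 bears on the place but compares two small alkyl groups only; no measured compound carries a group of this size, with a ring and a hydrogen-bond acceptor, at this nitrogen, so the expectation rests on little. A modest rise in the number is expected, with wide uncertainty. For compound 3 the estimated result in this assay is 8 nM, with a range from 2 nM to 35 nM. This estimate means an expected step of a 2.4-fold higher number from compound 2 to compound 3 (0.37 log units; beyond the scatter).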

Compound 3, half-maximal effective concentration: 1430 nM
Compound 3: the middle estimate sits 180-fold (2.25 log units) below what was measured, outside the stated range (above it).
By their numbers in this assay, from the lowest: compound 2; then compound 1; then compound 3.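

Under this assay, the aromatic nitrogen proves far more sensitive than the two small alkyl groups indicated: 1-acetylpiperidin-4-yl in place of isopropyl gives a 420-fold higher number from compound 2 to compound 3 (2.63 log units; beyond the scatter), and in place of cyclopropylmethyl it gives a 74-fold higher number from compound 1 to compound 3 (1.87 log units; beyond the scatter). This single change brings in several features at once: 9 heavy atoms against 3, a six-membered non-aromatic ring with 1 hetero atom, and 1 hydrogen-bond acceptor, and the three compounds cannot separate their contributions. No measurement at hand accounts for the rise.

Open, going by these compounds, is whether an all-carbon cyclohexyl group at this nitrogen would give a number closer to that of compound 2 or to that of compound 3. Equally open, on these data alone, is how a piperidin-4-yl group with a free ring amine, lacking the acetyl, would compare with compound 3.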